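Methoxycarbonyl to benzyloxycarbonyl: estimate for compound 4

A few compounds are considered here, and "the series" means these few. Any claim that something is new, unique, unknown or untested is made for them only; others in the source may bear on it.

In a functional assay on MDA-MB-231 cells (Homo sapiens) for antiproliferative activity, read by MTT assay, with a stated time of 48 h (on this read-out higher numbers stand for weaker inhibition of growth and lower numbers for stronger inhibition of growth), compound 1 `COC(=O)N1N=C(c2cccc(OC)c2)CC1c1cc(OC)c(OC)c(OC)c1` gives 350 nM, compound 2 `COC(=O)N1N=C(c2ccc(OC)cc2)CC1c1cc(OC)c(OC)c(OC)c1` gives 1990 nM, and compound 3 `COC(=O)N1N=C(c2cccc(O)c2)CC1c1cc(OC)c(OC)c(OC)c1` gives 740 nM, the second highest of the three numbers. Compound 4 `COc1cc(C2CC(c3cccc(O)c3)=NN2C(=O)OCc2ccccc2)cc(OC)c1OC` differs from compound 3 in one place: phenyl in place of hydrogen on a saturated chain carbon bound to an oxygen next to a carbonyl group. Methoxycarbonyl thus becomes benzyloxycarbonyl. Among the measured compounds shown here, no measured step touches this place, so the direction remains poorly supported. The steps of a 5.7-fold higher number from compound 1 to compound 2 (0.75 log units; beyond the scatter), a 2.1-fold higher number from compound 1 to compound 3 (0.33 log units; beyond the scatter) and a 2.7-fold lower number from compound 2 to compound 3 (0.43 log units; beyond the scatter) are all modest and serve only as a guide to size. A modest change toward a higher number is expected, with the estimated step of a 1.5-fold higher number from compound 3 to compound 4 (0.17 log units; within the scatter). For compound 4, the estimate in this assay is 1100 nM, with an expected range of 300 nM to 4000 nM.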

Compound 4, concentration for 50% growth inhibition: > 10000 nM
Compound 4 ended at the assay's limit; the forecaster's own chance of this, stated with the estimate: 3%; middle value at least 9.0-fold (0.95 log units) from the limit.
By their numbers in this assay, from the lowest: compound 1; then compound 3; then compound 2. At a limit, above all of these: compound 4.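

In this assay, phenyl in place of hydrogen on a saturated chain carbon bound to an oxygen next to a carbonyl group gives an at least 13-fold higher number from compound 3 to compound 4 (1.13 log units; beyond the scatter). Among the compounds shown here, the earlier steps, all modest, left this place untouched, so this is the first sign that growth inhibition responds strongly to a change here. Compound 4 gives > 10000 nM, which is a limit and not a number: the limit of > 10000 nM in this assay, at which 1 of the 4 values shown sits.

From the compounds shown here alone, whether the loss belongs to the phenyl ring itself remains open. Ethyl, a longer chain or an amine at this place could separate the ring from the added chain length.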